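A few compounds are considered here, and "the series" means these few. Any claim that something is new, unique, unknown or untested is made for them only; others in the source may bear on it.

Working notes on the series. The shared core, an aryl enone bearing a methoxy group and an ether link, is carried by compound 1 `C#CCOc1ccc(/C=C/C(C)=O)cc1OC`, compound 2 `COc1cc(/C=C/C(C)=O)ccc1OCc1cn(-c2ccccc2OC)nn1` and compound 3 `COc1cc(/C=C/C(C)=O)ccc1OCc1cn(-c2ccc(C(F)(F)F)c(C(F)(F)F)c2)nn1`. In a functional assay on MCF7 cells (Homo sapiens) for antiproliferative activity, read by MTT assay, with a stated time of 48 h (on this read-out higher numbers stand for weaker inhibition and lower numbers for stronger inhibition), compound 1 gives 65400 nM; compound 2 gives 29100 nM; compound 3 gives 87400 nM. Compound 2 thus stands lowest of the three numbers: compound 1 sits beyond the scatter above it, and compound 3 further still, so among these three compound 2 is the strongest inhibitor, with compound 3 the weakest.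

Compound 4 `COc1cc(/C=C/C(C)=O)ccc1OCc1cn(-c2ccc(C=O)cc2)nn1` has not yet been measured. It differs from compound 2 in one place: 4-formylphenyl in place of 2-methoxyphenyl on an aromatic nitrogen. Going by the values given here, no step between two measured compounds isolates this kind of change, so there is no direct precedent. Compound 3 shows that a different substituted phenyl on the same ring nitrogen weakens inhibition, but that change is not the one made here. A small step toward a higher number, or none beyond the scatter, is expected from compound 2 to compound 4, as a 1.4-fold higher number from compound 2 to compound 4 (0.16 log units; within the scatter). For compound 4 in this assay an estimated value of 42000 nM is expected, within a range from 15000 nM to 120000 nM.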

Compound 4, half-maximal inhibitory concentration: 86400 nM
For compound 4 the middle estimate is 2.1-fold (0.31 log units) below the measured one; measured number inside the range.
By their numbers in this assay, from the lowest: compound 2; then compounds 1, 4 and 3 (each within the scatter of the next).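

In this assay, exchanging 2-methoxyphenyl for 4-formylphenyl on the aromatic nitrogen gives a 3.0-fold higher number from compound 2 to compound 4 (0.47 log units; beyond the scatter), the first listed step that isolates a change at this position. The leaving and entering groups have the same counts of heavy atoms and hydrogen-bond acceptors, so inhibition at this position shifts beyond the scatter even with those counts unchanged. Nothing measured here accounts for the step.

The step replaces the methoxy group with a formyl group and also alters where the substituent sits on the phenyl ring, so the shown compounds cannot separate these two changes. Also open, on these data alone, is how a plain phenyl, or a carboxylic acid or an amine in place of the formyl group, would behave at this position.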